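The source may hold more compounds than are shown below. What is called first, only, known or untested is meant among the compounds shown, and "the series" means these compounds.

In a functional assay on HepG2 cells (Homo sapiens) for cytotoxicity, read by MTT assay, with a stated time of 24 h (a lower number here means a stronger inhibitor, a higher number a weaker inhibitor), compound 1 `CN1C/C(=C\c2cccnc2)C(=O)/C(=C/c2ccccc2F)C1` carries methyl on an amine nitrogen in a ring and gives 4810 nM as its reading. Compound 2 `O=C1/C(=C/c2cccnc2)CNC/C1=C\c1ccccc1F` carries hydrogen there and gives 21000 nM as its reading. Compound 3 `O=C1/C(=C/c2cccnc2)CN(S(=O)(=O)c2ccc(F)cc2)C/C1=C\c1ccccc1F` carries (4-fluorophenyl)sulfonyl there and gives 15600 nM as the second highest of the three numbers, level within the scatter with compound 2 and on the weaker side of compound 1.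

Next is compound 4 `O=C1/C(=C/c2cccnc2)CN(S(=O)(=O)c2ccc(Cl)cc2)C/C1=C\c1ccccc1F`, with chloro in place of fluoro on an aromatic carbon, para to a large group, on a six-membered aromatic ring of carbon only. The counted difference is chloro in place of fluoro on an aromatic carbon and nothing else changes.

Within the data shown here, no measured pair tests this exchange directly, since all three steps sit on the ring nitrogen. Replacing methyl gave a 4.4-fold higher number from compound 1 to compound 2 (0.64 log units; beyond the scatter) with hydrogen and a 3.2-fold higher number from compound 1 to compound 3 (0.51 log units; beyond the scatter) with (4-fluorophenyl)sulfonyl, both modest. Replacing hydrogen with that whole sulfonyl group gave only a 1.3-fold lower number from compound 2 to compound 3 (0.13 log units; within the scatter) and so offers the closest guide to scale. An exchange confined to one substituent on that group is therefore expected to stay within the scatter, without a firm direction. The expected step is a 1.1-fold lower number from compound 3 to compound 4 (0.05 log units; within the scatter) and no more than that is anticipated. Compound 4 is expected at 14000 nM and between 7000 nM and 28000 nM in four of five measurements.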

Compound 4, half-maximal inhibitory concentration: 12400 nM
Estimate against measurement, compound 4: 1.1-fold (0.05 log units) above; measured number inside the range.
By their numbers in this assay, from the lowest: compound 1; then compounds 4, 3 and 2 (each within the scatter of the next).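

Among these compounds, replacing 4-fluorophenyl with 4-chlorophenyl in this assay gives a 1.3-fold lower number from compound 3 to compound 4 (0.10 log units; within the scatter), the first reading at a position other than the ring nitrogen, and it shows that this exchange on an aromatic carbon, para to a large group, stays within the scatter. The (4-chlorophenyl)sulfonyl group gives a 1.7-fold lower number from compound 2 to compound 4 (0.23 log units; within the scatter) when it replaces hydrogen and a 2.6-fold higher number from compound 1 to compound 4 (0.41 log units; beyond the scatter) when it replaces methyl, so the sulfonyl compounds and the compound with hydrogen on the ring nitrogen remain apart from compound 1, which has the lowest number of the four, with each of its steps beyond the scatter. No available evidence bears on why these readings fall as they do.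

With only fluoro and chloro at this aromatic carbon, the series leaves open whether a larger or differently charged substituent there, such as methoxy, an amine or a carboxylic acid, would give a step beyond the scatter. As far as these compounds go, on the ring nitrogen, it also remains open whether a longer chain such as propyl in place of methyl would keep, lower or raise the number seen with compound 1.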